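The compounds below may be only part of what the source reports. "The series", "measured", "known", "first", "only" and "open" are said of these compounds alone.

Measured so far: compound 1 `C[C@H](NC(=O)c1c(Cc2ccc(C(C)(C)C)cc2)sc2c1CCOC2)c1ccc(C(=O)O)cc1` gives 9.5 nM in a functional assay on CHO/Galpha16 cells for antagonist activity at prostaglandin E2 receptor EP4 subtype (Homo sapiens), read by calcium flux, with a stated time of 15 min; a lower number here means a stronger inhibitor, a higher number a weaker inhibitor; compound 2 `COc1cccc(C#Cc2sc3c(c2C(=O)N[C@@H](C)c2ccc(C(=O)O)cc2)CCOC3)c1` gives 12.4 nM in the same assay.

Compound 2 stands beside compound 1, since a 1.3-fold higher number from compound 1 to compound 2 (0.12 log units; within the scatter) falls within the scatter, so the two numbers cannot be ordered. Compound 3 `C[C@H](NC(=O)c1c(C#Cc2ccc(F)cc2)sc2c1CCOC2)c1ccc(C(=O)O)cc1` differs from compound 2 by 4-fluorophenyl in place of 3-methoxyphenyl on a triple-bonded carbon. Within the data shown here, no measured step bears directly on this change; the only step available, from compound 1 to compound 2, replaced the whole arm at this position without a change beyond the scatter. For compound 3, therefore, the expected step of a 1.0-fold lower number from compound 2 to compound 3 (0.01 log units; within the scatter) is none beyond the scatter. Compound 3 is estimated at 12 nM, within 4 nM to 36 nM.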

Compound 3, half-maximal inhibitory concentration: 15.8 nM
Beside the measured number, compound 3's estimate is 1.3-fold (0.12 log units) below it; low and high end bracket the measured number.
By their numbers in this assay, from the lowest: compounds 1, 2 and 3 (each within the scatter of the next).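

In this assay the 4-fluorophenyl takes the place of 3-methoxyphenyl on the triple-bonded carbon with no step beyond the scatter (a 1.3-fold higher number from compound 2 to compound 3 (0.11 log units; within the scatter)), so the aryl group at the end of the arm can differ, carrying fluorine rather than a methoxy oxygen, without separating the two numbers. The 2-(4-fluorophenyl)ethynyl arm also stays within the scatter of the 4-(tert-butyl)benzyl arm (a 1.7-fold higher number from compound 1 to compound 3 (0.22 log units; within the scatter)), so the three arms cannot be ordered. Nothing on hand offers an explanation for these results. From the compounds shown here alone, it remains open whether an aryl group bearing an amine or a nitrile, or a plain propyl chain with no ring, would stay within the same range.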